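A few compounds are considered here, and "the series" means these few. Any claim that something is new, unique, unknown or untested is made for them only; others in the source may bear on it.

Measured compounds:
compound 1 `CCCCCCNc1ccc(C(=O)O)cc1S(=O)(=O)N(C)C` — 19.8%
compound 2 `CN(C)S(=O)(=O)c1cc(C(=O)O)ccc1NCCCC(F)(F)F` — 1.9%

Compound 2 stands lowest of the two numbers in an assay on HEK293 cells for inhibition of solute carrier family 12 member 2 (Homo sapiens), read by fluorescence, with a stated time of 30 min, tested at 100 uM; on this read-out lower numbers stand for a weaker effect and higher numbers for a stronger effect at the one concentration tested; its nearest neighbour is compound 1, whose value lies higher by the step of a number 17.9 percentage points lower from compound 1 to compound 2 (beyond the scatter), which is beyond the scatter. Going by the values given here, the only measured step is this one, trifluoromethyl in place of propyl on a saturated chain carbon, three bonds along the chain from a nitrogen on an aromatic ring, and it was modest in size.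

Compound 3 `CN(C)S(=O)(=O)c1cc(C(=O)O)ccc1NCCCCCC(F)(F)F` has not been measured. Relative to compound 2 the change is 3,3,3-trifluoropropyl in place of trifluoromethyl on a saturated chain carbon, three bonds along the chain from a nitrogen on an aromatic ring. Among the compounds with values here, this runs in the opposite sense to the measured step in terms of chain length while keeping the trifluoromethyl group, so a partial return toward the value of compound 1 is the most that can be read from the single step available; it is the only step that bears on the change, and nothing here separates the effect of the chain length from that of the fluorines.

For compound 3 the expected step in this assay is a number 8.1 percentage points higher from compound 2 to compound 3 (within the scatter), upward from compound 2. The estimated value for compound 3 is 10%, within the range -5% to 25%.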

Compound 3, a percentage reported as inhibition, at one concentration (the size of the read-out at that concentration, not a potency): 12.6%
For compound 3 the middle estimate is 2.6 percentage points below the measured one, and the stated range covers the measured number.
By their numbers in this assay, from the lowest: compound 2; then compounds 3 and 1 (each within the scatter of the next).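

In this assay, 3,3,3-trifluoropropyl in place of trifluoromethyl at this place gives a number 10.7 percentage points higher from compound 2 to compound 3 (beyond the scatter), so the low reading of compound 2 does not extend to every chain ending in trifluoromethyl. Trifluoromethyl in place of methyl, five bonds along the chain from a nitrogen on an aromatic ring, gives a number 7.2 percentage points lower from compound 1 to compound 3 (within the scatter), which separates the two changes that the earlier step from compound 1 to compound 2 carried together: among these three compounds, the fluorines at equal chain length leave the reading within the scatter, while the change in chain length with trifluoromethyl kept moves it beyond the scatter. No measurement offered here explains either step.

A longer chain ending in trifluoromethyl, or a chain of the same length ending in a nitrile or an amine, would show whether the reading depends on chain length alone or also on the group at the chain end. From the compounds shown here alone, all three readings come from one concentration, so whether the compounds would keep the same stronger or weaker effect at other concentrations remains open, as does the effect of replacing the carboxylic acid with a primary amide on any of these chains.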